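This account rests on a few compounds, and the source may have more. Where it says the series, first, only, none or still open, it means among the compounds named here.

Compound 1 `O=C1COc2ccc(-c3cccc(NS(=O)(=O)c4ccc(F)cc4)c3)cc2N1` carries a hydrogen on the amide-type nitrogen of its ring. In a functional assay on HepG2 cells (Homo sapiens) for antiproliferative activity, read by MTT assay, with a stated time of 72 h (on this read-out lower numbers stand for stronger inhibition and higher numbers for weaker inhibition), compound 1 gives only a limit, > 40000 nM, a value that sits at the limit of > 40000 nM in this assay, at which 1 of the 3 values shown sits. Compound 2 `O=C1COc2ccc(-c3cccc(NS(=O)(=O)c4ccc(F)cc4)c3)cc2N1c1ccc(Cl)cc1` is built from the same core by 4-chlorophenyl in place of hydrogen on an amide-type nitrogen in a ring; in this assay compound 2 gives 27800 nM, so the change brought an at least 1.4-fold lower number from compound 1 to compound 2 (0.15 log units; that floor lies within the scatter).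

Compound 3 `O=C1COc2ccc(-c3cnc4ccccc4c3)cc2N1` rests on a different core; the difference between the two cores is not broken down here. In this assay compound 3 gives 26300 nM, a value that lies within the scatter of the value of compound 2.

Compound 4 `O=C1COc2ccc(-c3cnc4ccccc4c3)cc2N1c1ccc(Cl)cc1` has not yet been measured. It arises from compound 3 by 4-chlorophenyl in place of hydrogen on an amide-type nitrogen in a ring, the same change, at the same place, that led from compound 1 to compound 2. As far as these compounds go, for compound 4 the expected step is a 1.8-fold lower number from compound 3 to compound 4 (0.24 log units; within the scatter), an expectation resting on the earlier step of an at least 1.4-fold lower number from compound 1 to compound 2 (0.15 log units; that floor lies within the scatter), whose floor lies within the scatter and whose true size is unknown. Compound 4 is therefore estimated at 15000 nM, with the likely range running from 6000 nM to 40000 nM.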

Compound 4, half-maximal inhibitory concentration: 32700 nM
Beside the measured number, compound 4's estimate is 2.2-fold (0.34 log units) below it; the measured number falls inside the stated range.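

On the core of compound 3, 4-chlorophenyl in place of hydrogen on the amide-type nitrogen gives a 1.2-fold higher number from compound 3 to compound 4 (0.09 log units; within the scatter) in this assay, so compound 3 and compound 4 cannot be told apart on this read-out. Set beside the earlier case, the comparison between the two cores stays undecided: the same change on two cores in this assay, an at least 1.4-fold lower number (0.15 log units; that floor lies within the scatter) from compound 1 to compound 2 and a 1.2-fold higher number (0.09 log units; within the scatter) from compound 3 to compound 4; the limit leaves it open whether they differ

As far as these compounds go, this shows that the modest gain suggested by the first pair did not appear as a measurable gain on the second core, but it does not show that the change behaves differently on the two cores, nor that it behaves alike, as the true size of the first step is unknown.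

The compounds shown carry only hydrogen or 4-chlorophenyl on this nitrogen, which leaves open what a methyl group, a longer alkyl chain or a phenyl ring without chlorine would do there. From the compounds shown here alone, it also remains open whether a group carrying an amine or a carboxylic acid at this place would give a clearer step on either core.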